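Replacing the triazole in compound 1 with a linked oxadiazolone

The source may hold more compounds than are shown below. What is called first, only, known or untested is meant among the compounds shown, and "the series" means these compounds.

Measured compounds:
- compound 1, `CC(C)C(c1nnc[nH]1)c1ccc(-c2ccc3cccc(F)c3c2)[nH]c1=O`: 0.213 h
- compound 2, `CC(C)C(Nc1nccs1)c1ccc(-c2ccc3cccc(F)c3c2)[nH]c1=O`: 0.0733 h
- compound 3, `CC(C)C(Cc1ncc[nH]1)c1ccc(-c2ccc3cccc(F)c3c2)[nH]c1=O`: < 0.0667 h

In an ADME assay on microsomes from liver (Mus musculus) for metabolic stability (on this read-out lower numbers stand for a shorter-lived compound and higher numbers for a longer-lived compound), compound 1 gives 0.213 h and stands highest of the two numbers. Compound 2 gives 0.0733 h in this assay. The value of compound 3 in this assay, < 0.0667 h, is a limit of the assay and not a number (the limit of < 0.0667 h in this assay, at which 1 of the 3 values shown sits). Compound 4, `CC(C)C(Cc1noc(=O)[nH]1)c1ccc(-c2ccc3cccc(F)c3c2)[nH]c1=O`, has not been measured. It differs from compound 1 by a group of 7 heavy atoms (3 carbon, 2 nitrogen, 2 oxygen; one five-membered aromatic ring with 3 hetero atoms) in place of a group of 5 heavy atoms (2 carbon, 3 nitrogen; one five-membered aromatic ring with 3 hetero atoms), on a saturated chain carbon bound to an aromatic carbon and a saturated chain carbon.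

Both measured steps from compound 1 bear on this change: a 2.9-fold lower number from compound 1 to compound 2 (0.46 log units; beyond the scatter) and an at least 3.1-fold lower number from compound 1 to compound 3 (0.50 log units; beyond the scatter). Both replacements of the 4H-1,2,4-triazol-3-yl lowered the number, and the step to compound 3, which also inserts a methylene between the chain carbon and the ring, is the closer parallel. A lower number is therefore expected in this assay, most likely a modest one, with a fair chance that only a limit is reported. Compound 4 is estimated at 0.09 h, within 0.05 h to 0.2 h, which means an expected 2.4-fold lower number from compound 1 to compound 4 (0.37 log units; beyond the scatter).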

Compound 4, half-life: 2.78 h
Compound 4: the middle estimate sits 31-fold (1.49 log units) below what was measured, outside the stated range (above it).
By their numbers in this assay, from the lowest: compound 2; then compound 1; then compound 4. At a limit, below all of these: compound 3.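

In this assay, the linked oxadiazolone reverses the direction seen so far at this saturated chain carbon, giving a 13-fold higher number from compound 1 to compound 4 (1.12 log units; beyond the scatter), whereas both earlier replacements of the 4H-1,2,4-triazol-3-yl lowered the number. A methylene link does not by itself shorten the half-life, since swapping only the ring on that link gives an at least 41-fold higher number from compound 3 to compound 4 (1.61 log units; beyond the scatter), and the comparison with the (1,3-thiazol-2-yl)amino group gives a 38-fold higher number from compound 2 to compound 4 (1.58 log units; beyond the scatter). The value of compound 3 is a limit of the assay and not a number, so its step is only a floor: the limit of < 0.0667 h in this assay, at which 1 of the 4 values shown sits.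

The compounds shown do not separate the contribution of the oxadiazolone ring from that of its methylene link. On these data alone, it also remains open whether another group on the same link, such as a carboxylic acid or a tetrazole, would give a similarly long half-life.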